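The source may hold more compounds than are shown below. What is called first, only, known or untested is meant among the compounds shown, and "the series" means these compounds.

Measured compounds:
compound 1 `O=C1N/C(=C\c2ccc(Cl)cc2)C(=O)N1c1ccc(Cl)cc1` gives 35600 nM
compound 2 `O=C(O)c1ccc(N2C(=O)N/C(=C\c3ccc(O)cc3)C2=O)cc1` gives > 200000 nM

Of the compounds shown here, two have been measured in a functional assay on NCI-H292 cells (Homo sapiens) for antiproliferative activity; on this read-out lower numbers stand for stronger inhibition and higher numbers for weaker inhibition. Compound 1 `O=C1N/C(=C\c2ccc(Cl)cc2)C(=O)N1c1ccc(Cl)cc1` gives 35600 nM in this assay. Compound 2 `O=C(O)c1ccc(N2C(=O)N/C(=C\c3ccc(O)cc3)C2=O)cc1` returns only a limit of this assay, > 200000 nM, so no number is known for it. On the numbers shown, compound 2 thus stands at the edge of what this assay reports, as one of the two values recorded (the limit of > 200000 nM in this assay, at which 1 of the 2 values shown sits). Going by the values given here, no step between measured compounds that differ in a single place is available; the two values show only that compound 1 has a number and compound 2 does not.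

Compound 3 `O=C(NCC1CCCCC1)c1ccc(N2C(=O)N/C(=C\c3ccc(O)cc3)C2=O)cc1` is not yet measured. It differs from compound 2 in one place: (cyclohexylmethyl)amino in place of hydroxy on a carbonyl carbon. Among the compounds with values here, since no measured step of this kind exists, the expected size of the step from compound 2 to compound 3 in this assay, an at least 5.0-fold lower number from compound 2 to compound 3 (0.69 log units; beyond the scatter), rests on the guess that replacing the carboxy group with a (cyclohexylmethyl)carbamoyl group moves the compound back into the measurable range, towards stronger inhibition. Compound 3 is therefore estimated at 40000 nM, with a range from 8000 nM to 200000 nM, and a real chance that it too returns only a limit.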

Compound 3, half-maximal inhibitory concentration: > 200000 nM
Compound 3 ended at the assay's limit; the forecaster's own chance of this, stated with the estimate: 35%; middle value at least 5.0-fold (0.69 log units) away from the limit.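

Compound 2 and compound 3 both return only a limit of this assay, so the step between them, from carboxy to (cyclohexylmethyl)carbamoyl, cannot be read: the limit of > 200000 nM in this assay, at which 2 of the 3 values shown sit.

The compounds shown leave open what real numbers compound 2 and compound 3 would have in this assay, and so whether this change of group makes any difference at all.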